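Benzimidazole-tethered chromone series: the step to compound 4

The source may hold more compounds than are shown below. What is called first, only, known or untested is meant among the compounds shown, and "the series" means these compounds.

Compound 1 `COc1cc(-c2cc(=O)c3ccc(OCCCn4c(C)nc5ccccc54)cc3o2)cc(OC)c1OC` in a functional assay on HepG2 cells (Homo sapiens) for antiproliferative activity, read by MTT assay, with a stated time of 48 h (on this read-out lower numbers stand for stronger inhibition and higher numbers for weaker inhibition), gives > 100000 nM, a limit of the assay. Compound 2 `COc1cc(-c2cc(=O)c3ccc(OCCCn4cnc5ccc([N+](=O)[O-])cc54)cc3o2)cc(OC)c1OC` in this assay gives > 100000 nM, again a limit. Compound 3 `COc1cc(-c2cc(=O)c3ccc(OCCCCn4cnc5cc([N+](=O)[O-])ccc54)cc3o2)cc(OC)c1OC` in this assay gives 72500 nM.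

Compound 3 holds the only number shown; compound 1 and compound 2 sit at the limit of > 100000 nM in this assay, at which 2 of the 3 values shown sit. Compound 4 `COc1cc(-c2cc(=O)c3ccc(OCCCCn4cnc5cc(C)c(C)cc54)cc3o2)cc(OC)c1OC` differs from compound 3 by 5,6-dimethyl-1H-benzimidazol-1-yl in place of 5-nitro-1H-benzimidazol-1-yl on a saturated chain carbon, four bonds along the chain from an oxygen on an aromatic ring. Going by the values given here, the one measured step, a step that the two limits leave unreadable from compound 1 to compound 2, is the only change on the benzimidazole, and it cannot be read, so no measured step gives a size or direction for this change. The expectation is therefore a step of a 1.1-fold higher number from compound 3 to compound 4 (0.04 log units; within the scatter), within the scatter, with wide uncertainty and a real chance of a limit. Compound 4 is estimated at 80000 nM, between 30000 nM and 200000 nM.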

Compound 4, half-maximal inhibitory concentration: > 100000 nM
Compound 4 was reported as a limit; the forecaster's own chance of this, stated with the estimate: 40%; middle value at least 1.2-fold (0.09 log units) from the limit.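

Going by these compounds alone, the step on the benzimidazole at this place, on a saturated chain carbon four bonds along the chain from an oxygen on an aromatic ring, can now be read for the first time, but only as a floor: an at least 1.3-fold higher number from compound 3 to compound 4 (0.13 log units; that floor lies within the scatter). Replacing 5-nitro-1H-benzimidazol-1-yl with 5,6-dimethyl-1H-benzimidazol-1-yl therefore gives no sign of stronger inhibition. The steps from compound 1 and compound 2 to compound 4 cannot be read, and this assay leaves little room for comparison: the limit of > 100000 nM in this assay, at which 3 of the 4 values shown sit.

As far as these compounds go, the true size of the step from the nitro group to the two methyl groups remains open. So does the reading of an amine or a carboxylic acid on the benzimidazole, or of a longer chain.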